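A few compounds are considered here, and "the series" means these few. Any claim that something is new, unique, unknown or untested is made for them only; others in the source may bear on it.

Measured so far in a functional assay on CHO cells for antagonist activity at adenosine receptor A2b (Homo sapiens), read by 33P incorporation, with a stated time of 20 min; a lower number here means a stronger inhibitor, a higher number a weaker inhibitor:

- compound 2 `CCn1c(-c2ccccc2)nc2c(NC3CCC3)ncnc21` gives 1440 nM
- compound 3 `Cn1c(-c2ccccc2)nc2c(NC3CCC3)ncnc21` gives 3730 nM
- compound 1 `Cn1c(-c2ccc(F)cc2)nc2c(NC3CCCC3)ncnc21` sits at > 30000 nM, which is a limit of this assay and not a number

Compound 2 stands lowest of the two numbers available. Its nearest neighbour is compound 3, with a 2.6-fold higher number from compound 2 to compound 3 (0.41 log units; beyond the scatter) for hydrogen in place of methyl on a saturated chain carbon bound to an aromatic nitrogen. Compound 1 is covered only by the limit of > 30000 nM in this assay, at which 1 of the 3 values shown sits.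

Compound 4 `CCn1c(-c2ccccc2)nc2c(NC3CCCC3)ncnc21` is not yet measured and differs from compound 2 by cyclopentyl in place of cyclobutyl on a nitrogen on an aromatic ring. For the measured compounds named here, none of the measured steps is this change. Compound 1 carries the cyclopentylamino group and is reported only as a limit. Compound 3 carries the cyclobutylamino group and gives a number, but compound 1 and compound 3 also differ in the fluorine on the phenyl, so that pair does not isolate the change. The expectation is a move to a higher number, estimated as a 3.5-fold higher number from compound 2 to compound 4 (0.54 log units; beyond the scatter), with a real chance of a limit. Compound 4 is estimated at 5000 nM, range 1500 nM to 30000 nM.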

Compound 4, inhibition constant: 5790 nM
Compound 4: the middle estimate sits 1.2-fold (0.06 log units) below what was measured; the range from low to high includes it.
By their numbers in this assay, from the lowest: compound 2; then compounds 3 and 4 (each within the scatter of the next). At a limit, above all of these: compound 1.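

In this assay, for the compounds shown here, cyclopentyl in place of cyclobutyl on a nitrogen on an aromatic ring gives a 4.0-fold higher number from compound 2 to compound 4 (0.60 log units; beyond the scatter), the first measured step at this position with the rest of the structure unchanged. This position therefore responds to ring size in this one pair, and the larger of the two rings gives the higher number. Compound 1 also carries the cyclopentylamino group, but it is reported only as a limit and gives no size for this change: the limit of > 30000 nM in this assay, at which 1 of the 4 values shown sits.

On these data alone, it remains open whether the same step appears with methyl in place of ethyl on the aromatic nitrogen, or with a fluorine on the phenyl. As far as these compounds go, the response to cyclopropyl, to an open chain such as n-butyl, or to a hydroxyl on the cyclopentyl ring also remains open.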